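Adding an Ethynyl Group to Compound 2

A few compounds are considered here, and "the series" means these few. Any claim that something is new, unique, unknown or untested is made for them only; others in the source may bear on it.

Compound 1 `C[Si](C)(C)c1cccc2[nH]ncc12`: 150000 nM
Compound 2 `OC(Cc1ccccc1)c1cccc2[nH]ncc12`: 31000 nM

Both were tested in an assay for binding affinity to Indoleamine 2,3-dioxygenase 1 (Homo sapiens), read by spectrophotometry, with a stated time of 30 min; a lower number here means tighter binding, a higher number weaker binding. Compound 2 gives the lowest of the two numbers, and compound 1 gives a higher one, a gap beyond the usual scatter. Compound 3 `C#Cc1cc(C(O)Cc2ccccc2)c2cn[nH]c2c1` differs from compound 2 in one place: ethynyl in place of hydrogen on an aromatic carbon. Going by the values given here, no comparison between measured compounds is available, so the effect of this change is unknown; a modest step in either direction, or none beyond the scatter, is possible in this assay. Compound 3 is expected to give 15000 nM, between 3000 nM and 80000 nM. That would be an estimated step of a 2.1-fold lower number from compound 2 to compound 3 (0.32 log units; beyond the scatter), not a known one.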

Compound 3, dissociation constant: 7400 nM
Beside the measured number, compound 3's estimate is 2.0-fold (0.31 log units) above it; the measured number falls inside the stated range.
By their numbers in this assay, from the lowest: compound 3; then compound 2; then compound 1.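

In this assay, ethynyl in place of hydrogen on an aromatic carbon brings a 4.2-fold lower number from compound 2 to compound 3 (0.62 log units; beyond the scatter), a modest tightening of binding. This shows that the position, para to a fused ring, accepts a small carbon group and that binding improves rather than suffers. Nothing shown here explains this step. From the compounds shown here alone, whether a methyl, a nitrile or an amine at the same position would give a similar step remains open. So does whether the triple bond itself matters, which a comparison with an ethyl group could test.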